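Chloro on the core of compound 1

The source may hold more compounds than are shown below. What is called first, only, known or untested is meant among the compounds shown, and "the series" means these compounds.

In an ADME assay on Vero cells (Chlorocebus sabaeus) for cytotoxicity, read by CellTiter-Glo, with a stated time of 72 h (on this read-out lower numbers stand for higher toxicity in this test and higher numbers for lower toxicity in this test), compound 1 (`[O-][n+]1nc(NC2CCC2)[n+]([O-])c2ccccc21`) gives 8.9 ug/mL and is level with compound 2 (`[O-][n+]1nc(NC2CCCCC2)[n+]([O-])c2ccccc21`) at 8.9 ug/mL. Compound 3 (`COCC(C)Nc1n[n+]([O-])c2ccccc2[n+]1[O-]`) gives > 50 ug/mL, which is a limit of the assay and not a number. Compound 4 (`[O-][n+]1nc(NC2CCC2)[n+]([O-])c2ccc(Cl)cc21`) differs from compound 1 by one change: chloro in place of hydrogen on an aromatic carbon. The measured steps, no change at the digits printed from compound 1 to compound 2 (within the scatter) and an at least 5.6-fold higher number from compound 1 to compound 3 (0.74 log units; beyond the scatter), alter only the group on nitrogen, so neither bears directly on the aromatic carbon. Within the data shown here, no measured step shows a substitution there. The expected step in this assay is a 1.3-fold lower number from compound 1 to compound 4 (0.10 log units; within the scatter), with none beyond the scatter anticipated. Compound 4 is estimated at 7 ug/mL, within a range of 2.5 ug/mL to 20 ug/mL.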

Compound 4, half-maximal cytotoxic concentration: 1.6 ug/mL
For compound 4 the middle estimate is 4.4-fold (0.64 log units) above the measured one; measured number below the stated range.
By their numbers in this assay, from the lowest: compound 4; then compounds 1 and 2 (each within the scatter of the next). At a limit, above all of these: compound 3.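

Chloro in place of hydrogen on an aromatic carbon gives a 5.6-fold lower number from compound 1 to compound 4 (0.75 log units; beyond the scatter) in this assay, so a change on the shared core, and not only on the group on nitrogen, moves this read-out, here toward higher toxicity in this test. The data shown offer no cause for this step.

On these data alone, whether an amine, a carboxylic acid or methoxy on this carbon would move the number in the same way remains open. Also open, as far as these compounds go, is whether chloro acts alike with the 1-(methoxymethyl)ethyl group of compound 3, whose > 50 ug/mL is a limit and not a number.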